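A Chloro Analogue Weighed Against Its Fluoro Parent

A few compounds are considered here, and "the series" means these few. Any claim that something is new, unique, unknown or untested is made for them only; others in the source may bear on it.

Compound 1 `CC(CC[C@H]1/C(=C/c2ccc([N+](=O)[O-])cc2)CC[C@H]2C(C)(C)CCC[C@]12C)CC(=O)O` is measured in a functional assay on THP-1 cells (Homo sapiens) for cytotoxicity, read by MTT assay, with a stated time of 72 h (a lower number here means a stronger inhibitor, a higher number a weaker inhibitor), at 68000 nM. Compound 2 `CC(CC[C@H]1/C(=C/c2ccc(F)cc2)CC[C@H]2C(C)(C)CCC[C@]12C)CC(=O)O` reaches only the limit of the assay, > 200000 nM, so its number is not known. The step of an at least 2.9-fold higher number from compound 1 to compound 2 (0.46 log units; beyond the scatter) rests on (the limit of > 200000 nM in this assay, at which 1 of the 2 values shown sits). Compound 3 `CC(CC[C@H]1/C(=C/c2ccc(Cl)cc2)CC[C@H]2C(C)(C)CCC[C@]12C)CC(=O)O` differs from compound 2 by chloro in place of fluoro on an aromatic carbon. Among the measured compounds shown here, no measured step swaps fluoro for chloro; the nitro-to-fluoro step bears on it only by placing compound 2 at the edge of the measurable range. One therefore expects an at least 1.3-fold lower number from compound 2 to compound 3 (0.12 log units; that floor lies within the scatter), a step within the scatter. Compound 3 is estimated at 150000 nM, between 60000 nM and 350000 nM.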

Compound 3, half-maximal inhibitory concentration: > 200000 nM
Compound 3 gave a limit, no number; the forecaster's own chance of this, stated with the estimate: 55%; at least 1.3-fold (0.12 log units) between middle value and limit.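

In this assay, chloro on the aromatic carbon para to a large group gives an at least 2.9-fold higher number from compound 1 to compound 3 (0.46 log units; beyond the scatter), the same kind of step that fluoro gave, so nitro now stands apart from two halogens rather than one. The step between compound 2 and compound 3 cannot be read, and no order between the two halogens follows. The values now gather at one edge of the range: the limit of > 200000 nM in this assay, at which 2 of the 3 values shown sit.

Going by these compounds, whether an amine or a nitrile in this place would give a measurable number stays open. So does how far compound 2 and compound 3 truly lie from compound 1.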